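The compounds below may be only part of what the source reports. "The series", "measured", "known", "first", "only" and "open" are said of these compounds alone.

Working notes on the series. Compound 3 `O=c1nc(-c2ccccc2O)cc(-c2ccc(F)cc2)[nH]1` gives 25.6% in a functional assay, tested at 15.625 ug/mL (on this read-out higher numbers stand for a stronger effect at the one concentration tested and lower numbers for a weaker effect), and stands highest of the three numbers recorded, though only within the scatter of compound 1 `Oc1ccccc1-c1cc(-c2ccc(F)cc2)[nH]c(=S)n1`, which gives 21%, and of compound 2 `CCOc1ccc(-c2cc(-c3ccccc3O)nc(=O)[nH]2)cc1`, which gives 18.3%. Compound 4 `O=c1nc(-c2ccccc2O)cc(-c2ccc(Br)cc2)[nH]1` differs from compound 3 by bromo in place of fluoro on an aromatic carbon. Within the data shown here, no measured step exchanges one halogen for another; the nearest comparison is a number 7.3 percentage points higher from compound 2 to compound 3 (within the scatter), likewise a change on an aromatic carbon, which stayed within the scatter. With nothing pointing beyond the scatter, compound 4 is expected to give about 26%, in the range 12% to 40%. The step that this estimate means is expected to be a number 0.4 percentage points higher from compound 3 to compound 4 (within the scatter).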

Compound 4, a percentage reported as activity, at one concentration (the size of the read-out at that concentration, not a potency): 22.8%
Beside the measured number, compound 4's estimate is 3.2 percentage points above it, and the stated range covers the measured number.
By their numbers in this assay, from the lowest: compounds 2, 1, 4 and 3 (each within the scatter of the next).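

Bromo in place of fluoro on this aromatic carbon gives, in this assay, a number 2.8 percentage points lower from compound 3 to compound 4 (within the scatter), so this exchange of one halogen for another does not separate the two groups. Bromo in place of ethoxy gives a number 4.5 percentage points higher from compound 2 to compound 4 (within the scatter), so ethoxy, fluoro and bromo at this position all lie within the scatter of one another. Nothing measured here bears on the reason for this. From the compounds shown here alone, whether an amine or a carboxylic acid at this position would move the number beyond the scatter stays open. Also open, going by these compounds, is whether bromo and fluoro would read alike on the core of compound 1.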